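Swapping the Distal Aryl Group on a Shared Amide Core

The source may hold more compounds than are shown below. What is called first, only, known or untested is meant among the compounds shown, and "the series" means these compounds.

Compound 1, `CCOC(=O)CCCCCOc1cccc(CN(C(=O)c2ccc(-c3cnc(OC)nc3OC)cc2)C(C)C)c1`. In an ADME assay on HEK293 cells (Homo sapiens) for cytotoxicity, read by CellTiter-Glo and resazurin assay, with a stated time of 72 h (on this read-out higher numbers stand for an effect only at larger amounts of compound and lower numbers for an effect already at smaller amounts), compound 1 gives > 26000 nM, a limit of the assay.
Compound 2, `CCOC(=O)CCCCCOc1cccc(CN(C(=O)c2ccc(-c3ccoc3)cc2)C(C)C)c1`. In this assay compound 2 gives > 26000 nM, again only a limit.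
Compound 3, `CCOC(=O)CCCCCOc1cccc(CN(C(=O)c2ccc(-c3ccc4c(c3)OCCO4)cc2)C(C)C)c1`. In this assay compound 3 gives > 24400 nM, likewise a limit.

Compound 3 therefore stands at a limit in this assay, not at a measured number. The same holds for the rest of the set: the limit of > 26000 nM in this assay, at which 2 of the 3 values shown sit, and (the limit of > 24400 nM in this assay, at which 1 of the 3 values shown sits). As a result none of the steps between the measured compounds can be read: a step that the two limits leave unreadable from compound 1 to compound 2, a step that the two limits leave unreadable from compound 1 to compound 3 and a step that the two limits leave unreadable from compound 2 to compound 3 are all left open by the limits on both sides.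

The unmeasured compound 4, `CCOC(=O)CCCCCOc1cccc(CN(C(=O)c2ccc(-c3ccc(Cl)c(Cl)c3)cc2)C(C)C)c1`, differs from compound 3 at the same position that varies across the measured set: 3,4-dichlorophenyl in place of 2,3-dihydro-1,4-benzodioxin-6-yl on an aromatic carbon. The steps from compound 1 to compound 3 and from compound 2 to compound 3 bear on this exchange, but neither has a readable size, so no direction or size of step in this assay can be anticipated from them beyond the scatter. Compound 4 is accordingly estimated at 25000 nM, with a range from 8000 nM to 60000 nM. This estimate means a step that the limit leaves unreadable from compound 3 to compound 4, and a limit is expected to remain the likeliest outcome.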

Compound 4, half-maximal effective concentration: > 26000 nM
Compound 4 was reported as a limit (the forecaster's own chance of this, stated with the estimate: 60%); at least 1.0-fold (0.01 log units) between middle value and limit.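

Compound 4, like compound 1, compound 2 and compound 3, stands at a limit in this assay, so no step from any of these compounds to compound 4 can be read: the limit of > 26000 nM in this assay, at which 3 of the 4 values shown sit.

The compounds shown leave open at what amount of compound, if any, each of the exchanged groups would give a measurable effect in this assay.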